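Benzothiazole amide replacement in a DU-145 series

The compounds below may be only part of what the source reports. "The series", "measured", "known", "first", "only" and "open" are said of these compounds alone.

Measured compounds: compound 1 `COc1ccc2nc(NC(=O)c3cc(-c4ccc(OC)c(OC)c4)n4nc(-c5ccccc5)cc4n3)sc2c1` gives 14000 nM in a functional assay on DU-145 cells (Homo sapiens) for cytotoxicity, read by MTT assay, with a stated time of 48 h; a higher number here means a weaker inhibitor, a lower number a stronger inhibitor; compound 2 `COc1ccc2nc(NC(=O)c3cc(-c4cc(OC)c(OC)c(OC)c4)n4nc(-c5ccccc5)cc4n3)sc2c1` gives 3980 nM in this assay.

Compound 1 carries the highest of the two numbers. Its nearest neighbour is compound 2, with a 3.5-fold lower number from compound 1 to compound 2 (0.55 log units; beyond the scatter), a change of methoxy in place of hydrogen on an aromatic carbon of the aryl group that sits away from the amide.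

Compound 3 `COc1ccc(-c2cc(C(=O)Nc3nc4cc(C)c(C)cc4s3)nc3cc(-c4ccccc4)nn23)cc1OC` is not yet measured. It differs from compound 1 by 5,6-dimethyl-1,3-benzothiazol-2-yl in place of 6-methoxy-1,3-benzothiazol-2-yl on an amide-type nitrogen. Among the compounds with values here, nothing measured so far bears on this part of the molecule: the only known step, from compound 1 to compound 2, changes the other end of the shared core and leaves the benzothiazolyl amide untouched. Within the data shown here, no measured step therefore tells how the benzothiazolyl ring substituents affect the read-out.

The working expectation for compound 3 is a step of no clear direction, no change at the digits printed from compound 1 to compound 3 (within the scatter), within the usual scatter. Compound 3 is estimated at 14000 nM, with a range from 5000 nM to 40000 nM.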

Compound 3, half-maximal inhibitory concentration: 6910 nM
For compound 3 the middle estimate is 2.0-fold (0.31 log units) above the measured one; low and high end bracket the measured number.
By their numbers in this assay, from the lowest: compounds 2 and 3 (each within the scatter of the next); then compound 1.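

In this assay, the amide end of the series responds to a ring change: 5,6-dimethyl-1,3-benzothiazol-2-yl in place of 6-methoxy-1,3-benzothiazol-2-yl on the amide-type nitrogen gives a 2.0-fold lower number from compound 1 to compound 3 (0.31 log units; beyond the scatter), so the read-out is not fixed by the aryl end alone, the only end varied in the earlier step. The lower number comes with no change in the heavy-atom count of the group, with a carbon taking the place of the oxygen and one hydrogen-bond acceptor fewer, but this single swap removes the methoxy and adds two methyl groups at once, so the contribution of each cannot be separated. Nothing measured here accounts for the step.

A bare 1,3-benzothiazol-2-yl, or the same ring with a single methyl or a chlorine, would show whether losing the methoxy or gaining the methyl groups carries the step. Also open, as far as these compounds go, is whether the extra methoxy of compound 2 and the 5,6-dimethyl-1,3-benzothiazol-2-yl group, taken together in one molecule, would lower the number further in this assay.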